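A few compounds are considered here, and "the series" means these few. Any claim that something is new, unique, unknown or untested is made for them only; others in the source may bear on it.

Measured so far:
- compound 1, `COc1ccc(-n2c(S)nnc2-c2cc(OC)c(OC)c(OC)c2)cc1`: > 60000 nM
- compound 2, `COc1ccc(CSc2nnc(-c3cc(OC)c(OC)c(OC)c3)n2-c2ccc(OC)cc2)cc1`: 49600 nM

Notes on the series. Compound 1, `COc1ccc(-n2c(S)nnc2-c2cc(OC)c(OC)c(OC)c2)cc1`, carries hydrogen on the sulfur; in a functional assay on HCT-116 cells (Homo sapiens) for inhibition, read by MTT assay, with a stated time of 48 h (a higher number here means a weaker inhibitor, a lower number a stronger inhibitor), compound 1 returns only a limit, > 60000 nM. Within the data shown here, compound 2, `COc1ccc(CSc2nnc(-c3cc(OC)c(OC)c(OC)c3)n2-c2ccc(OC)cc2)cc1`, carries 4-methoxybenzyl on that sulfur and in this assay compound 2 gives 49600 nM, the only actual number in the set so far. Among the measured compounds shown here, the one step in hand, an at least 1.2-fold lower number from compound 1 to compound 2 (0.08 log units; that floor lies within the scatter), rests on the limit of > 60000 nM in this assay, at which 1 of the 2 values shown sits, and its floor sits inside the scatter, so it fixes no direction of its own.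

Compound 3, `COc1ccc(-n2c(SCC(=O)C3CC3)nnc2-c2cc(OC)c(OC)c(OC)c2)cc1`, is not yet measured. It differs from compound 2 by cyclopropylcarbonyl in place of 4-methoxyphenyl on a saturated chain carbon bound to a sulfur. For the measured compounds named here, no measured step touches this exchange: the only step in hand concerns what hangs on the sulfur as a whole, not the substituent on the chain carbon. The change is therefore taken as neutral within the scatter, with wide uncertainty. For compound 3 in this assay the expected value is 45000 nM, in the range 15000 nM to 110000 nM. The step this implies, a 1.1-fold lower number from compound 2 to compound 3 (0.04 log units; within the scatter), is an estimate only.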

Compound 3, half-maximal inhibitory concentration: > 60000 nM
Compound 3: only a limit was reported (the forecaster's own chance of this, stated with the estimate: 35%); middle value at least 1.3-fold (0.12 log units) away from the limit.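

In this assay compound 3 returns only a limit, > 60000 nM. Cyclopropylcarbonyl in place of 4-methoxyphenyl on a saturated chain carbon bound to a sulfur gives an at least 1.2-fold higher number from compound 2 to compound 3 (0.08 log units; that floor lies within the scatter), so this first measured exchange at this place fixes no direction, and nothing in it sets the 4-methoxybenzyl compound apart from the (cyclopropylcarbonyl)methyl compound. The step from compound 1 to compound 3 cannot be read, and the only actual number in the set remains that of compound 2, so the sulfur position is so far bounded rather than measured: the limit of > 60000 nM in this assay, at which 2 of the 3 values shown sit.

The exchange replaces the aromatic ring and brings in both a carbonyl and a cyclopropyl ring at once, and the compounds shown do not separate these parts from one another. Also open, going by these compounds, is how a benzyl group without the methoxy, a longer chain, an amine or a carboxylic acid on the sulfur would read in this assay, and whether any group at this position gives a number clearly apart from that of compound 2.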